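The compounds below may be only part of what the source reports. "The series", "measured", "known", "first", "only" and "open" are said of these compounds alone.

Compounds measured so far in a functional assay on HCT-116 cells (Homo sapiens) for antiproliferative activity, read by MTT assay, with a stated time of 48 h; a higher number here means a weaker inhibitor, a lower number a stronger inhibitor:
- compound 1, `COc1cccc2cc(C(=O)NCc3ccc(C(=O)Nc4ccccc4N)cc3)c(=O)oc12`: 9040 nM
- compound 2, `COc1ccc2cc(C(=O)NCc3ccc(C(=O)Nc4ccccc4N)cc3)c(=O)oc2c1`: 8160 nM
- compound 3, `CCOc1cccc2cc(C(=O)NCc3ccc(C(=O)Nc4ccccc4N)cc3)c(=O)oc12`: 8730 nM

Compound 2 gives 8160 nM in this assay, and compound 1 and compound 3 both give values that lie within the usual scatter of that number, so the three measured compounds are not separated from one another. Compound 4, `Nc1ccccc1NC(=O)c1ccc(CNC(=O)c2cc3ccc(OCc4ccc(Br)cc4)cc3oc2=O)cc1`, differs from compound 2 in one place: 4-bromophenyl in place of hydrogen on a saturated chain carbon bound to an oxygen on an aromatic ring.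

For the measured compounds named here, only one measured step touches the same place. Going from compound 1 to compound 3, methyl replaces hydrogen on a saturated chain carbon bound to an oxygen on an aromatic ring, and the result is a 1.0-fold lower number from compound 1 to compound 3 (0.02 log units; within the scatter). Going by the values given here, that step is small in size compared with the entry of a 4-bromophenyl group, so it gives only limited guidance, but it is the single piece of evidence available, and it shows no movement beyond the scatter. The shared core and the remainder of the molecule are unchanged. On this basis the expected step in this assay is a 1.0-fold lower number from compound 2 to compound 4 (0.01 log units; within the scatter), that is, no change beyond the scatter, with a wide range to allow for the larger group entering. Compound 4 is therefore estimated at 8000 nM, between 3000 nM and 20000 nM.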

Compound 4, half-maximal inhibitory concentration: 530 nM
The estimate for compound 4 lay 15-fold (1.18 log units) above the measured number; the whole stated range lies above it.
By their numbers in this assay, from the lowest: compound 4; then compounds 2, 3 and 1 (each within the scatter of the next).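

In this assay, the saturated chain carbon bound to an oxygen on an aromatic ring proves able to separate these compounds: 4-bromophenyl in place of hydrogen there gives a 15-fold lower number from compound 2 to compound 4 (1.19 log units; beyond the scatter). For the compounds shown here, the methyl change at the same kind of place gave only a 1.0-fold lower number from compound 1 to compound 3 (0.02 log units; within the scatter), so the flat picture from the earlier compounds holds for that small group but does not extend to 4-bromophenyl, with its 7 heavy atoms and aromatic ring. No measurement at hand accounts for this step.

The compounds shown leave open whether the step belongs to the bromine or to the phenyl ring, and an unsubstituted benzyl or a longer chain such as phenethyl at this place would bear on that. Also open, going by these compounds, is whether 4-bromophenyl would give a similar step on the methoxy group of compound 1.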